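This account rests on a few compounds, and the source may have more. Where it says the series, first, only, none or still open, it means among the compounds named here.

Compound 1, `COc1nc2ccc(Br)cc2cc1C(c1ccccc1)n1cc(C2CC2)nn1`, stands highest of the three compounds measured in an ADME assay on PANC-1 cells (Homo sapiens) for cytotoxicity, read by sulforhodamine B assay, with a stated time of 48 h, tested at 10 uM (a higher number here means more inhibition at the concentration tested (going by the name of the read-out), a lower number less inhibition), where compound 1 gives 21.8%. Compound 2, `COc1nc2ccc(Br)cc2cc1C(c1ccccc1)n1cc(-c2ccccc2F)nn1`, gives 14.7% in this assay, and compound 3, `CCCCc1cn(C(c2ccccc2)c2cc3cc(Br)ccc3nc2OC)nn1`, gives 5.46%. The step of a number 7.1 percentage points lower from compound 1 to compound 2 (within the scatter) lies within the scatter, whereas a number 16.3 percentage points lower from compound 1 to compound 3 (beyond the scatter) reaches beyond it; between the two other compounds, a number 9.2 percentage points lower from compound 2 to compound 3 (within the scatter) again stays within the scatter.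

The compound not yet measured is compound 4, `COc1nc2ccc(Br)cc2cc1C(c1ccccc1)n1cc(-c2ccc(F)cc2)nn1`. It differs from compound 1 in one place: 4-fluorophenyl in place of cyclopropyl on an aromatic carbon. Of the measured steps, the one that bears most directly on this change is a number 7.1 percentage points lower from compound 1 to compound 2 (within the scatter), since it also swaps the cyclopropyl for a fluorine-bearing aromatic ring on the aromatic carbon of the shared core. The step of a number 16.3 percentage points lower from compound 1 to compound 3 (beyond the scatter) is the only one beyond the scatter, but it concerns a butyl chain rather than a ring. Going by the values given here, the two aromatic groups carry their fluorine differently, and no measured pair tests that difference on its own. Compound 4 is therefore expected to land close to compound 1 or somewhat lower, the estimated step being a number 6.8 percentage points lower from compound 1 to compound 4 (within the scatter), not clearly beyond the scatter. The estimate for compound 4 in this assay is 15%, with a range from 5% to 26%.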

Compound 4, a percentage reported as inhibition, at one concentration (the size of the read-out at that concentration, not a potency): 14.9%
Compound 4: middle estimate off by 0.1 percentage points, on the high side; measured number inside the range.
By their numbers in this assay, from the lowest: compounds 3, 2, 4 and 1 (each within the scatter of the next, the first and the last beyond it).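

In this assay, going by these compounds alone, the move from 2-fluorophenyl to 4-fluorophenyl at this position gives a number 0.2 percentage points higher from compound 2 to compound 4 (within the scatter), so the two placements of fluorine on the aromatic ring cannot be told apart here, a comparison that the earlier compounds did not offer. The new ring also sits within the scatter of both earlier neighbours, with a number 6.9 percentage points lower from compound 1 to compound 4 (within the scatter) against the cyclopropyl group and a number 9.4 percentage points higher from compound 3 to compound 4 (within the scatter) against the butyl chain, so that compound 4 separates from neither, even though the step of a number 16.3 percentage points lower from compound 1 to compound 3 (beyond the scatter) between those two neighbours is beyond the scatter. Nothing measured here gives a reason for these numbers.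

Going by these compounds, what remains open is whether plain phenyl, 3-fluorophenyl or a ring with more than one fluorine would behave like the two fluorophenyl compounds at this aromatic carbon of the five-membered ring. On these data alone, it is also open whether an amine, a carboxylic acid or a longer chain at the same place would move the number beyond the scatter from compound 1 , and in which direction.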